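This account rests on a few compounds, and the source may have more. Where it says the series, first, only, none or still open, it means among the compounds named here.

Measured so far:
Compound 1 `Cc1cc(C#N)cc(C)c1Oc1cc(Nc2ccc(C#N)cc2)c([N+](=O)[O-])cc1[N+](=O)[O-]`: > 58200 nM
Compound 2 `Cc1cc(C)c(Oc2cc(Nc3ccc(C#N)cc3)c([N+](=O)[O-])cc2[N+](=O)[O-])c(C)c1`: > 59800 nM

In an ADME assay on H9 cells (Homo sapiens) for cytotoxicity, read by XTT assay, with a stated time of 6 days (on this read-out higher numbers stand for lower toxicity in this test and lower numbers for higher toxicity in this test), compound 1 gives > 58200 nM, which is a limit of the assay rather than a number. Compound 2 gives > 59800 nM in this assay, again only a limit. Compound 2 therefore stands at the limit, as does the other value shown, and the step that the two limits leave unreadable from compound 1 to compound 2 cannot be read. Compound 3 `Cc1cc(C=O)cc(C)c1Oc1cc(Nc2ccc(C#N)cc2)c([N+](=O)[O-])cc1[N+](=O)[O-]` differs from compound 2 by formyl in place of methyl on an aromatic carbon. Within the data shown here, no measured step bears readably on this change. The author expects the step that the limit leaves unreadable from compound 2 to compound 3 to be none beyond the scatter. Compound 3 is estimated at 60000 nM, within 20000 nM to 150000 nM.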

Compound 3, half-maximal cytotoxic concentration: 57900 nM
Compound 3: the middle estimate sits 1.0-fold (0.02 log units) above what was measured; the measured number falls inside the stated range.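

In this assay compound 3 gives 57900 nM, the first true number shown at this position, para to a large group, with formyl in place of methyl. On these data alone, measured against the limit of compound 2, this change reads as an at least 1.0-fold lower number from compound 2 to compound 3 (0.01 log units; that floor lies within the scatter), so formyl shows no step beyond the scatter, though its full size stays open. Formyl in place of cyano reads as a number no higher from compound 1 to compound 3 (the limit leaves the size open) and no size can be given. Compound 1 remains a limit rather than a number: the limit of > 58200 nM in this assay, at which 1 of the 3 values shown sits.

As far as these compounds go, what an amine or a carboxylic acid would give at this position remains open. So does whether a longer chain there would give a clearly lower number in this assay.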